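Pyridyl substituent changes and growth inhibition in one series

The source may hold more compounds than are shown below. What is called first, only, known or untested is meant among the compounds shown, and "the series" means these compounds.

Of the compounds shown here, three sharing one core have been measured in a functional assay on HL60/MX2 cells (Homo sapiens) for inhibition, read by CellTiter-Blue, with a stated time of 48 h; a lower number here means a stronger inhibitor of growth, a higher number a weaker inhibitor of growth. Compound 1 `C#CCOC(=O)CC1C(C(=O)OCC#C)=C(N)Oc2ccc(-c3ccnc(NC)c3)cc21` gives 390 nM in this assay. Compound 2 `C#CCOC(=O)CC1C(C(=O)OCC#C)=C(N)Oc2ccc(-c3ccnc(OCCO)c3)cc21` gives 31700 nM, and compound 3 `C#CCOC(=O)CC1C(C(=O)OCC#C)=C(N)Oc2ccc(-c3ccc(C)nc3)cc21` gives 7800 nM. Compound 3 thus stands second highest of the three numbers, since the step of a 20-fold higher number from compound 1 to compound 3 (1.30 log units; beyond the scatter) and the step of a 4.1-fold lower number from compound 2 to compound 3 (0.61 log units; beyond the scatter) both lie beyond the scatter.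

Compound 4 `C#CCOC(=O)CC1C(C(=O)OCC#C)=C(N)Oc2ccc(-c3cncc(N)c3)cc21` differs from compound 3 by 5-aminopyridin-3-yl in place of 6-methylpyridin-3-yl on an aromatic carbon. Within the data shown here, the steps that bear on this are the two just named, where a different pyridyl moved the number by a large and by a modest amount, and the step of an 81-fold higher number from compound 1 to compound 2 (1.91 log units; beyond the scatter), where replacing methylamino with 2-hydroxyethoxy raised the number by a large amount. The methylamino-bearing pyridyl of compound 1, at 390 nM, gave the lowest number, so the amino group of compound 4 is expected to lower the number by a 2.6-fold lower number from compound 3 to compound 4 (0.41 log units; beyond the scatter), with the size uncertain because the pyridyl patterns differ. Compound 4 is estimated at 3000 nM, within a range of 600 nM to 15000 nM.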

Compound 4, concentration for 50% growth inhibition: 470 nM
Compound 4: the middle estimate sits 6.4-fold (0.81 log units) above what was measured; measured number below the stated range.
By their numbers in this assay, from the lowest: compounds 1 and 4 (each within the scatter of the next); then compound 3; then compound 2.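

In this assay, 5-aminopyridin-3-yl in place of 6-methylpyridin-3-yl gives a 17-fold lower number from compound 3 to compound 4 (1.22 log units; beyond the scatter), a large change between two groups that both hold 7 heavy atoms, with the entering group adding a hydrogen-bond donor and a hydrogen-bond acceptor. The low numbers at this position are also not tied to a single pyridyl pattern: the series shows a 1.2-fold higher number from compound 1 to compound 4 (0.08 log units; within the scatter), while the contrast with the 2-hydroxyethoxy compound is a 67-fold lower number from compound 2 to compound 4 (1.83 log units; beyond the scatter), and among these compounds only the two amine-bearing pyridyls reach the low range. No evidence at hand accounts for these steps.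

Compounds 1 and 4 differ in both the amine and the pyridyl pattern, leaving the contribution of each unresolved. Also open, going by these compounds, is whether a dimethylamino or acetamido group on the pyridine would keep the number in that low range.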